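The source may report more compounds than this note shows. Statements on the series, on what has been measured and on what is new or still open speak of the compounds shown alone.

Measured compounds:
- compound 1 `ClCc1cccc(Cn2cnc3ncnc(Cl)c32)c1` — 13800 nM
- compound 2 `ClCc1ccc(Cn2cnc3c(Cl)nc(Cl)nc32)cc1` — 1740 nM

Two compounds of the series have numbers in a functional assay on RPMI-8226 cells (Homo sapiens) for cytotoxicity, read by sulforhodamine B assay, with a stated time of 48 h; on this read-out higher numbers stand for weaker inhibition of growth and lower numbers for stronger inhibition of growth. Compound 1 stands at the highest number of the two, with 13800 nM; the nearest, compound 2, sits at a lower number, 1740 nM, and the gap between the two lies beyond the scatter. Within the data shown here, no step between compounds that differ in one place only can be drawn, since compound 1 and compound 2 differ both in the substitution of the core and in the arrangement of the substituents on the benzyl ring.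

Compound 3 `ClCc1cccc(Cn2cnc3nc(Cl)nc(Cl)c32)c1` is not yet measured in this assay. Among the measured compounds shown here, it differs from compound 1 by chloro in place of hydrogen on an aromatic carbon, giving a dichloro core that matches the one of compound 2. For the measured compounds named here, the expectation rests on compound 2, whose value 1740 nM is the only number available for the dichloro core. The step in this assay is expected downward, beyond the scatter: a 4.9-fold lower number from compound 1 to compound 3 (0.69 log units; beyond the scatter). Compound 3 is thus estimated at 2800 nM, with a range from 900 nM to 8000 nM.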

Compound 3, concentration for 50% growth inhibition: 1690 nM
The estimate for compound 3 lay 1.7-fold (0.22 log units) above the measured number; measured number inside the range.
By their numbers in this assay, from the lowest: compounds 3 and 2 (each within the scatter of the next); then compound 1.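

Compound 3 gives the series its first comparison that turns on a single place: in this assay, adding chloro in place of hydrogen on the aromatic carbon between two ring nitrogen atoms gives an 8.2-fold lower number from compound 1 to compound 3 (0.91 log units; beyond the scatter). The earlier pair could not show this, as compound 1 and compound 2 differ in more than one place, so the contribution of this position could not be separated from the rest of the structure. Here the rest of compound 1 stays unchanged and the step lies beyond the scatter, which marks this carbon as a place where substitution changes growth inhibition in these cells, although nothing available on the compounds bears on the reason for the step.

Going by these compounds, this remains a single step for a single group in a single cell line, so it is open whether the shift is specific to chloro or would also appear with an amine, a methoxy group or a methyl group on the same carbon. On these data alone, it is also open whether a step of similar size would appear with the substituents on the benzyl ring arranged as in compound 2.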